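Ether chain swaps on a shared aminoquinoline core

The source may hold more compounds than are shown below. What is called first, only, known or untested is meant among the compounds shown, and "the series" means these compounds.

Measured compounds in an assay on cells with melanin-concentrating hormone receptor 1 (Homo sapiens) as the target, read by radioligand binding; on this read-out higher numbers stand for weaker inhibition and lower numbers for stronger inhibition:
Compound 1, `COCCOCCOc1cccc2ccc(N)nc12`: compound 1 reaches only a limit of the assay, > 2000 nM.
Compound 2, `Nc1ccc2cccc(OCCC3CCCCC3)c2n1`: compound 2 gives 808 nM.
Compound 3, `CC(C)(C)CCOc1cccc2ccc(N)nc12`: compound 3 gives 201 nM.

Compound 3 stands lowest of the two numbers measured, with compound 2 nearest; the step of a 4.0-fold lower number from compound 2 to compound 3 (0.60 log units; beyond the scatter) lies beyond the scatter, as does an at least 9.9-fold lower number from compound 1 to compound 3 (0.99 log units; beyond the scatter). The step of an at least 2.4-fold lower number from compound 1 to compound 2 (0.39 log units; beyond the scatter) is smaller but also beyond the scatter, with compound 1 sitting at the limit of > 2000 nM in this assay, at which 1 of the 3 values shown sits.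

Compound 4, `Nc1ccc2cccc(OC3CCC3)c2n1`, differs from compound 3 in one place: cyclobutyl in place of 3,3-dimethylbutyl on an oxygen on an aromatic ring. The steps measured so far all change the group on the same ether oxygen, and each time a larger, branched or ring-bearing alkyl group brought a lower number than a smaller or oxygen-containing one. Cyclobutyl is smaller than either 3,3-dimethylbutyl or the chain of compound 2, so a higher number than compound 3 is expected, by about a 4.0-fold higher number from compound 3 to compound 4 (0.60 log units; beyond the scatter). Compound 4 is therefore estimated at 800 nM, within a range from 150 nM to 4000 nM.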

Compound 4, half-maximal inhibitory concentration: > 2000 nM
Compound 4: a limit, no number; the forecaster's own chance of this, stated with the estimate: 20%; middle value at least 2.5-fold (0.39 log units) from the limit.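

Compound 1, compound 2 and compound 3 differ only two bonds along the chain from the oxygen, whereas here the whole group on the oxygen changes. The swap brings an at least 9.9-fold higher number from compound 3 to compound 4 (0.99 log units; beyond the scatter) even though both groups hold carbon only, so an all-carbon group on this oxygen does not by itself give a low number. Compound 4 reaches only a limit of the assay, the same limit as compound 1: the limit of > 2000 nM in this assay, at which 2 of the 4 values shown sit.

The compounds shown leave open whether the ring or the smaller group carries this step, as the change alters both at once, and a straight butyl chain on the same oxygen would tell the two apart. Going by these compounds, the effect of an amine at the end of the chain also stays open.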